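The compounds below may be only part of what the source reports. "The series", "measured", "known", "first", "only" and "open" are said of these compounds alone.

Working notes on the series

Compound 2 `Cn1ccc(-c2ccccc2NCC2=NCCN2)n1` stands lowest of the two numbers measured in a functional assay with Alpha-1A adrenergic receptor (Homo sapiens) as the target, read by calcium flux; on this read-out higher numbers stand for larger maximal responses and lower numbers for smaller maximal responses: compound 2 gives 116%, whereas compound 1 `c1ccc(-c2nc[nH]n2)c(NCC2=NCCN2)c1` gives 135%. Among the measured compounds shown here, the one step measured so far, a number 19 percentage points lower from compound 1 to compound 2 (beyond the scatter), came with 1-methyl-1H-pyrazol-3-yl in place of 1H-1,2,4-triazol-3-yl on an aromatic carbon.

Compound 3 `Cn1ccnc1-c1ccccc1NCC1=NCCN1` is the next member. Its change from compound 2 is 1-methyl-1H-imidazol-2-yl in place of 1-methyl-1H-pyrazol-3-yl on an aromatic carbon. The step from compound 1 to compound 2 is the only one that bears on this change, and it exchanged one five-membered aromatic ring with two hetero atoms for another, much as here; it was modest in size and went downward. From compound 2 to compound 3 the expected step in this assay is therefore a number 6 percentage points lower from compound 2 to compound 3 (within the scatter), small and not clearly beyond the scatter. For compound 3 the estimated maximal response is 110%, expected to fall between 90% and 130%.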

Compound 3, largest response reached (reported as maximal response), in percent of the reference or control that the assay uses: 88%
For compound 3 the middle estimate is 22 percentage points above the measured one, outside the stated range (below it).
By their numbers in this assay, from the lowest: compound 3; then compound 2; then compound 1.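

In this assay, a number 28 percentage points lower from compound 2 to compound 3 (beyond the scatter), although the two groups exchanged have the same heavy atoms and the same counts of hydrogen-bond donors and acceptors; at this position, the arrangement of atoms within the ring is therefore enough to shift the maximal response beyond the scatter. The wider comparison, a number 47 percentage points lower from compound 1 to compound 3 (beyond the scatter), extends the range of responses seen at this position to a large step. No measurement on hand accounts for the difference between these isomeric rings.

On these data alone, the share of the N-methyl group remains open, as 1H-1,2,4-triazol-3-yl differs from both methylated rings in more than that group alone; 1H-imidazol-2-yl would separate it from the ring change. Also open, as far as these compounds go, is how a carboxylic acid or a primary amine on the same aromatic carbon would compare with these rings.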